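The source may hold more compounds than are shown below. What is called first, only, known or untested is meant among the compounds shown, and "the series" means these compounds.

Measured in a functional assay on MCF7 cells (Homo sapiens) for antiproliferative activity, read by MTT assay, with a stated time of 48 h, tested at 25 uM; a lower number here means a stronger effect, a higher number a weaker effect of the compound at the concentration tested:
compound 1 `OC(CCn1nc2c(Br)c(Br)c(Br)c(Br)c2n1)c1ccc(F)cc1` gives 97%
compound 2 `COc1cccc(C(O)CCn2nc3c(Br)c(Br)c(Br)c(Br)c3n2)c1` gives 96%
compound 3 `C[C@@H](O)CCn1nc2c(Br)c(Br)c(Br)c(Br)c2n1` gives 77%

Compound 1 stands highest of the three numbers in this assay; compound 2 is nearest, and compound 3 furthest, beyond the scatter. Compound 4 `CC(O)CCn1nc2c(Br)c(Br)c(Br)c(Br)c2n1` is unmeasured. From compound 1 it differs by methyl in place of 4-fluorophenyl on a saturated chain carbon bound to an oxygen on a saturated carbon and a saturated chain carbon. Among the measured compounds shown here, the only measured step, a number 1 percentage points lower from compound 1 to compound 2 (within the scatter), swaps one aryl group for another and bears little on this change. Compound 3, which carries methyl at the same place, gives 77% in this assay, so for compound 4 a downward step is expected, roughly a number 20 percentage points lower from compound 1 to compound 4 (beyond the scatter). The expected number for compound 4 is 77%, with a range of 65% to 90%.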

Compound 4, a percentage reported as activity, at one concentration (the size of the read-out at that concentration, not a potency): 73%
Compound 4: middle estimate off by 4 percentage points, on the high side, within the range that was stated.
By their numbers in this assay, from the lowest: compounds 4 and 3 (each within the scatter of the next); then compounds 2 and 1 (each within the scatter of the next).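

In this assay, methyl at this place gives the stronger effect against either aryl group: a number 24 percentage points lower from compound 1 to compound 4 (beyond the scatter) and a number 23 percentage points lower from compound 2 to compound 4 (beyond the scatter). The change therefore reads the same whether 4-fluorophenyl or 3-methoxyphenyl leaves. The remaining step, a number 4 percentage points lower from compound 3 to compound 4 (within the scatter), shows no readable effect of how the stereocentre is drawn, and the pair differs only in this: the fact that one of compounds 3 and 4 is drawn with a defined configuration and the other without, at the place where they differ

Going by these compounds, what the opposite configuration gives on its own stays open. So does whether an ethyl group, a cyclohexyl ring or an amine at this place would follow methyl or the aryl groups.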